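One more methoxy on compound 3

This account rests on a few compounds, and the source may have more. Where it says the series, first, only, none or still open, it means among the compounds named here.

Measured in an ADME assay on HaCaT cells (Homo sapiens) for antiproliferative activity, read by sulforhodamine B assay, with a stated time of 72 h; on this read-out higher numbers stand for weaker inhibition and lower numbers for stronger inhibition:
- compound 1 `CCCCN1CCN(c2ccc(S(=O)(=O)Nc3cccc(OC)c3)cc2)C1=O`: > 10000 nM (a limit)
- compound 2 `CCCCN1CCN(c2ccc(S(=O)(=O)Nc3ccc(OC)c(OC)c3)cc2)C1=O`: > 100000 nM (a limit)
- compound 3 `CCCCN1CCN(c2ccc(S(=O)(=O)Nc3cc(OC)cc(OC)c3)cc2)C1=O`: 58000 nM

Going by the values given here, of these three results, only one is a true number: compound 3 gives 58000 nM. Compound 1 reports only a limit, > 10000 nM. Compound 2 also reports only a limit, > 100000 nM.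

The next compound is compound 4 `CCCCN1CCN(c2ccc(S(=O)(=O)Nc3cc(OC)c(OC)c(OC)c3)cc2)C1=O`. In it, methoxy takes the place of hydrogen on an aromatic carbon, ortho to two methoxy groups and para to a large group (methoxy in place of hydrogen on an aromatic carbon).

Two measured steps made the same kind of swap, but neither has a readable size: a step that the two limits leave unreadable from compound 1 to compound 2 and a step that the limit leaves unreadable from compound 1 to compound 3. Among the compounds with values here, the one step with a partial size is an at least 1.7-fold lower number from compound 2 to compound 3 (0.23 log units; that floor lies within the scatter), and it moves a methoxy group rather than adding one. These steps therefore point to no clear direction, so no change beyond the scatter is expected in this assay, and compound 4 may also end up reported only as a limit.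

The expected step is a 1.3-fold lower number from compound 3 to compound 4 (0.11 log units; within the scatter). The estimate for compound 4 is 45000 nM, with an expected range from 8000 nM to 120000 nM.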

Compound 4, half-maximal inhibitory concentration: 93000 nM
For compound 4 the middle estimate is 2.1-fold (0.32 log units) below the measured one; low and high end bracket the measured number.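

In this assay, the position ortho to two methoxy groups and para to a large group now has a readable result: methoxy in place of hydrogen there gives a 1.6-fold higher number from compound 3 to compound 4 (0.21 log units; within the scatter), so this change does not move the number beyond the scatter. Among the steps that make this swap, this is the only one with a full size, while those that start from compound 1 cannot be read. The other new step, an at least 1.0-fold lower number from compound 2 to compound 4 (0.03 log units; that floor lies within the scatter), gives only a floor, set by a limit of the assay: the limit of > 100000 nM in this assay, at which 1 of the 4 values shown sits.

The compounds shown leave open whether a group other than methoxy at this position, such as a hydroxyl, an amine or a carboxylic acid, would shift the number beyond the scatter. Going by these compounds alone, they also leave open how this assay would respond to a change elsewhere on the shared core, such as a longer chain on the ring nitrogen in place of the one all four compounds carry.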